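The source may report more compounds than this note shows. Statements on the series, on what has been measured and on what is new or still open speak of the compounds shown alone.

Measured compounds:
Compound 1, `NCc1csc(NC(=O)c2ncccn2)n1`, gives -0.2 in a physicochemical assay for lipophilicity, read by HPLC, at pH 3.0; on this read-out higher numbers stand for higher lipophilicity and lower numbers for lower lipophilicity.
Compound 2, `NCc1csc(NC(=O)c2cc3ccccc3[nH]2)n1`, gives 1.1 in this assay.
Compound 3, `Cc1csc(NC(=O)c2cc(C(C)(C)C)nn2Cc2ccccc2)n1`, gives 4.7 in this assay.

Among these three, compound 3 stands highest in this assay. Its nearest neighbour is compound 2, whose value lies well below it, beyond the scatter, and compound 1 lies further still, also beyond the scatter. Among the measured compounds shown here, the three compounds share no single-point relationship with one another, so no measured step is available to anchor a prediction; the only guide is the change itself and the value of compound 3.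

Compound 4, `CC(C)(C)c1cc(C(=O)Nc2ccccc2)n(Cc2ccccc2)n1`, differs from compound 3 in one place: phenyl in place of 4-methyl-1,3-thiazol-2-yl on an amide-type nitrogen. The change therefore swaps one six-atom aromatic ring for another of the same size on the amide-type nitrogen, removing two hydrogen-bond acceptors and both ring hetero atoms.

For the measured compounds named here, with no comparable step in hand, the expected step from compound 3 to compound 4 is a modest rise in this assay, estimated as a number 0.40 log units higher from compound 3 to compound 4 (beyond the scatter), which may or may not clear the scatter. Compound 4 is accordingly expected to read 5.1 in this assay, with a plausible range from 4.5 to 5.7.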

Compound 4, distribution coefficient: 4.7
For compound 4 the middle estimate is 0.40 log units above the measured one; the measured number falls inside the stated range.
By their numbers in this assay, from the lowest: compound 1; then compound 2; then compounds 3 and 4 (each within the scatter of the next).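

In this assay, among the compounds shown here, the first one-place comparison reads no change at the digits printed from compound 3 to compound 4 (within the scatter), for phenyl in place of 4-methyl-1,3-thiazol-2-yl on an amide-type nitrogen. At this place, then, a ring with hetero atoms and hydrogen-bond acceptors gives way to a ring of carbon only with no such acceptors, and the read-out does not separate the two compounds. Nothing at hand gives a measured reason why these two compounds read alike.

The compounds shown leave open whether this holds for this single pair only or also for other groups on the same nitrogen, such as a saturated cyclohexyl ring, or a phenyl ring carrying a carboxylic acid or a dimethylamino group. For the compounds shown here, they also leave open how the aminomethyl group of compound 1 and compound 2 would read on the thiazole ring of compound 3, since both of those compounds differ from it in more than one place and offer no single step to compare.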